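The source may hold more compounds than are shown below. What is called first, only, known or untested is meant among the compounds shown, and "the series" means these compounds.

Compound 1 `CCCCOc1ccc2c(Cl)ccnc2c1`: 2740 nM in a functional assay on HCT-116 cells (Homo sapiens) for cytotoxicity, read by MTT assay, with a stated time of 48 h; a higher number here means a weaker inhibitor, a lower number a stronger inhibitor
Compound 2 `Clc1ccnc2cc(OCCc3ccccc3)ccc12`: 2180 nM in this assay

Compound 1 has the highest of the two numbers measured in this assay; its nearest neighbour is compound 2, and the step of a 1.3-fold lower number from compound 1 to compound 2 (0.10 log units; within the scatter) lies within the scatter, so the two compounds cannot be placed in order. Compound 3 `CC(C)Oc1ccc2c(Cl)ccnc2c1` has not yet been measured. It differs from compound 1 in one place: isopropyl in place of butyl on an oxygen on an aromatic ring. For the measured compounds named here, only one measured step exists, the one from compound 1 to compound 2, and it concerns a change two bonds out along the chain rather than the chain attached to the oxygen on the aromatic ring itself; its size, a 1.3-fold lower number from compound 1 to compound 2 (0.10 log units; within the scatter), is within the scatter. Going by the values given here, no measured step therefore bears directly on the replacement of butyl by isopropyl, and the one step available shows that a change on the group attached to the oxygen on the aromatic ring left the number essentially where it was. On that basis the step of a 1.1-fold higher number from compound 1 to compound 3 (0.04 log units; within the scatter) is expected to be small, with no direction beyond the scatter. Compound 3 is estimated at 3000 nM, within the range 1200 nM to 7500 nM.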

Compound 3, half-maximal inhibitory concentration: 2590 nM
Compound 3: the middle estimate sits 1.2-fold (0.06 log units) above what was measured, and the stated range covers the measured number.
By their numbers in this assay, from the lowest: compounds 2, 3 and 1 (each within the scatter of the next).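

In this assay, for the compounds shown here, replacing butyl with isopropyl on an oxygen on an aromatic ring gives a 1.1-fold lower number from compound 1 to compound 3 (0.02 log units; within the scatter), the first measured step that alters the group attached directly to that oxygen. Taking the group from 4 heavy atoms to 3, or butoxy to isopropoxy, therefore does not separate the two compounds, and a 1.3-fold lower number from compound 1 to compound 2 (0.10 log units; within the scatter) likewise leaves its pair unseparated, so neither of the two changes shown on this side chain moves the number beyond the scatter. No other measurement accompanies these numbers to say what lies behind them.

The compounds shown leave open whether this insensitivity holds only for the plain hydrocarbon groups among them, or whether an amine or a carboxylic acid carried on the chain attached to the oxygen would shift the number beyond the scatter. They also leave open whether a much longer chain, such as decyl, or a bare hydroxyl group in place of the whole alkoxy group would give a number that could be told apart from those of compound 1, compound 2 and compound 3.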